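Growing the Side Chain: Ethyl to Tert-Butyl

A few compounds are considered here, and "the series" means these few. Any claim that something is new, unique, unknown or untested is made for them only; others in the source may bear on it.

Measured compounds:
- compound 1, `[O-][n+]1cccc(Oc2ccccc2)c1`: 100 mg/kg
- compound 2, `CCc1cc[n+]([O-])cc1Oc1ccccc1`: 30 mg/kg

Both compounds were tested in a functional assay on the whole organism with Mus musculus as the target, in the maximal electroshock model, with a stated time of 30 min; on this read-out lower numbers stand for an effect already at smaller amounts and higher numbers for an effect only at larger amounts of compound. Compound 1 carries no side chain on the ring carbon in question and gives 100 mg/kg. Among the measured compounds shown here, compound 2 carries an ethyl there and gives 30 mg/kg, the lowest of the two numbers measured; the single measured step, a 3.3-fold lower number from compound 1 to compound 2 (0.52 log units; beyond the scatter), is beyond the scatter and came with ethyl in place of hydrogen on an aromatic carbon.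

Compound 3, `CC(C)(C)c1cc[n+]([O-])cc1Oc1ccccc1`, continues in the same direction: tert-butyl in place of ethyl on an aromatic carbon. For the measured compounds named here, the only step that bears on it is the ethyl-for-hydrogen step just described, which lowered the number modestly. A tert-butyl is a further enlargement of the same group at the same place, so a step of similar or smaller size, again toward a lower number, is expected, with no change beyond the scatter also plausible. The expected step is a 1.5-fold lower number from compound 2 to compound 3 (0.18 log units; within the scatter). Compound 3 is therefore estimated to give 20 mg/kg, within a range from 8 mg/kg to 60 mg/kg.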

Compound 3, minimum effective dose: 30 mg/kg
Compound 3: middle estimate off by 1.5-fold (0.18 log units), on the low side, and the stated range covers the measured number.
By their numbers in this assay, from the lowest: compounds 2 and 3 (each within the scatter of the next); then compound 1.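

In this assay, enlarging the group opposite the ring nitrogen from ethyl, with 2 heavy atoms, to tert-butyl, with 4 heavy atoms, gives no change at the digits printed from compound 2 to compound 3 (within the scatter), so the added bulk of carbon brings no readable change at this place. Set against the compound with only hydrogen there, the tert-butyl group gives a 3.3-fold lower number from compound 1 to compound 3 (0.52 log units; beyond the scatter), a step of the same printed size as the one seen with ethyl, which shows that a larger branched group keeps the gain and does not add to it across these compounds. No measurement here explains why the number stays put when the group grows.

The compounds shown leave open whether the gain needs a group as large as ethyl at all, since a methyl at this place would test the small end of the series, and whether a longer chain such as hexyl would keep the number or lose it. They also leave open whether a group of a different kind here, such as an amine or a carboxylic acid, would fit the same picture.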